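This account rests on a few compounds, and the source may have more. Where it says the series, first, only, none or still open, it means among the compounds named here.

Compound 1 `COc1cc(CNCc2ccncc2)ccc1OCc1ccc(Cl)cc1`: 890 nM
Compound 2 `COc1cc(CNCCCN(C)C)ccc1OCc1ccc(Cl)nc1`: 5000 nM
Compound 3 `COc1cc(CNc2nc[nH]n2)ccc1OCc1ccc(Cl)nc1`: 69000 nM

In a functional assay on HeLa cells (Homo sapiens) for inhibition, with a stated time of 72 h (a higher number here means that more compound is needed for the effect, a lower number that less compound is needed), compound 3 stands highest of the three numbers, with compound 2 closest and compound 1 furthest from it. Compound 4 `COc1cc(CNCc2cccnc2)ccc1OCc1ccc(Cl)nc1` differs from compound 3 by (pyridin-3-yl)methyl in place of 1H-1,2,4-triazol-3-yl on an amine nitrogen. For the measured compounds named here, the one measured step that bears on this site is a 14-fold higher number from compound 2 to compound 3 (1.14 log units; beyond the scatter), a large rise when the 1H-1,2,4-triazol-3-yl group entered. Its departure in compound 4 is expected to undo that rise, and compound 1, which also carries a pyridinylmethyl group on the amine nitrogen, gives 890 nM. Compound 4 is therefore expected to show a 46-fold lower number from compound 3 to compound 4 (1.66 log units; beyond the scatter) in this assay. The estimate for compound 4 is 1500 nM, with a range from 400 nM to 6000 nM.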

Compound 4, half-maximal effective concentration: 5000 nM
Compound 4: middle estimate off by 3.3-fold (0.52 log units), on the low side; low and high end bracket the measured number.
By their numbers in this assay, from the lowest: compound 1; then compounds 2 and 4 (each within the scatter of the next); then compound 3.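

With (pyridin-3-yl)methyl on the amine nitrogen, a 14-fold lower number from compound 3 to compound 4 (1.14 log units; beyond the scatter) appears in this assay and so the high number of compound 3 is tied to 1H-1,2,4-triazol-3-yl rather than to this position as a whole. Pyridin-3-yl in place of 2-(dimethylamino)ethyl on the saturated chain carbon gives no change at the digits printed from compound 2 to compound 4 (within the scatter) and so these two groups are not told apart here. No measurement given here accounts for either step. Compound 1 differs from compound 4 in more than one place, so its lower number cannot be assigned to either place. On these data alone, how a (pyridin-2-yl)methyl group or a carboxylic acid on the amine nitrogen would read remains open.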